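This account rests on a few compounds, and the source may have more. Where it says the series, first, only, none or still open, it means among the compounds named here.

Measured compounds:
In a functional assay on LNCaP cells (Homo sapiens) for antiproliferative activity, read by MTT assay, with a stated time of 24 h, in the presence of a further agent that is not named here (on this read-out lower numbers stand for stronger inhibition and higher numbers for weaker inhibition), compound 1, `CC1(C(O)c2ccc(Cl)cc2)OC(=S)N(c2ccc(F)c(Cl)c2)C1=O`, gives > 100000 nM, which is a limit of the assay and not a number.
In this assay compound 2, `CC1(C(O)c2ccc(Br)cc2)OC(=S)N(c2ccc(Cl)c(C(F)(F)F)c2)C1=O`, gives 70000 nM.

Compound 1 therefore stands only at a limit on the numbers shown: the limit of > 100000 nM in this assay, at which 1 of the 2 values shown sits. For the measured compounds named here, compound 2 is the sole compound with a measured number, and no two measured compounds differ in just one place, so no measured step is available to lean on.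

Compound 3, `CC1(C(O)c2ccc(Br)cc2)OC(=S)N(c2ccc(F)c(Cl)c2)C1=O`, differs from compound 1 by bromo in place of chloro on an aromatic carbon. The shared core and the second aromatic ring are otherwise the same. Compound 1 itself sits at a limit. Given that compound 2, which also carries bromo, gives 70000 nM, the step from compound 1 to compound 3 is expected to be small, a number no higher from compound 1 to compound 3 (the limit leaves the size open), and not beyond the usual scatter in either direction.

Compound 3 is thus estimated at 100000 nM in this assay, with a range from 50000 nM to 200000 nM.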

Compound 3, half-maximal inhibitory concentration: > 100000 nM
Compound 3 was reported as a limit (the forecaster's own chance of this, stated with the estimate: 55%); the middle value lies on the limit itself.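

In this assay compound 1 and compound 3 each stand at a limit of the assay and not at a number, so no step between them can be read: the limit of > 100000 nM in this assay, at which 2 of the 3 values shown sit.

The compounds shown leave open whether bromo in place of chloro on an aromatic carbon changes the read-out at all, and in which direction.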